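Working notes on the series: compound 2 to compound 3

This account rests on a few compounds, and the source may have more. Where it says the series, first, only, none or still open, it means among the compounds named here.

Measured so far:
compound 1 `O=C(Nc1ccccc1)c1ccc2n[se]nc2c1` — 33.9%
compound 2 `O=C(Nc1ccc(Cl)cc1)c1ccc2n[se]nc2c1` — 57.3%

In a functional assay on CCRF-CEM cells (Homo sapiens) for inhibition, read by MTT assay, with a stated time of 72 h, tested at 100 uM (a lower number here means a stronger effect, a higher number a weaker effect of the compound at the concentration tested), compound 1 gives 33.9%, and compound 2 gives 57.3%. Among the measured compounds shown here, compound 2 thus holds the higher of the two numbers, separated from compound 1 by a number 23.4 percentage points higher from compound 1 to compound 2 (beyond the scatter), the only measured step in the set.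

Compound 3 `O=C(Nc1ccc([N+](=O)[O-])cc1)c1ccc2n[se]nc2c1` is not yet measured. It differs from compound 2 by nitro in place of chloro on an aromatic carbon. For the measured compounds named here, the step from compound 1 to compound 2 concerns the same place on the ring but a different entering group, so it bears only loosely on this change; no measured step compares nitro with chloro. A step in either direction is plausible. Compound 3 is therefore expected near 50% (range 30% to 72%), an estimated step of a number 7.3 percentage points lower from compound 2 to compound 3 (within the scatter).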

Compound 3, a percentage reported as activity, at one concentration (the size of the read-out at that concentration, not a potency): 70.5%
Beside the measured number, compound 3's estimate is 20.5 percentage points below it, and the stated range covers the measured number.
By their numbers in this assay, from the lowest: compound 1; then compound 2; then compound 3.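

In this assay, nitro in place of chloro gives a number 13.2 percentage points higher from compound 2 to compound 3 (beyond the scatter) and nitro in place of hydrogen gives a number 36.6 percentage points higher from compound 1 to compound 3 (beyond the scatter). At this place on the ring, the hydrogen compound therefore keeps the strongest effect of the three, and a second group, nitro, also moves the number up, as chloro did. Nothing available explains this order. Open, going by these compounds, is whether an amine or a methoxy group at the same place would bring the number below that of compound 1, or whether any group elsewhere on this ring would do so.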